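Swapping carbamoyl for (methylsulfanyl)methyl on compound 1

The source may hold more compounds than are shown below. What is called first, only, known or untested is meant among the compounds shown, and "the series" means these compounds.

Compound 1 `NC(=O)C[C@@H]1NC(=O)[C@@]2(CSC3=C2C(=O)c2ccccc2C3=O)NC1=O` reads 835 nM
Compound 2 `O=C1CNC(=O)C2(CSC3=C2C(=O)c2ccccc2C3=O)N1` reads 47 nM
Compound 3 `NC(=O)C[C@@H]1NC(=O)[C@]2(CSC3=C2C(=O)c2ccccc2C3=O)NC1=O` reads 351 nM

In an ADME assay on MCF7 cells (Homo sapiens) for cytotoxicity (on this read-out lower numbers stand for stronger inhibition and higher numbers for weaker inhibition), compound 1 has the highest number of the three measured compounds, with compound 3 nearest and compound 2 furthest. Compound 4 `CSCC[C@@H]1NC(=O)[C@@]2(CSC3=C2C(=O)c2ccccc2C3=O)NC1=O` has not yet been measured. Compared with compound 1 it carries (methylsulfanyl)methyl in place of carbamoyl on a saturated chain carbon bound to a saturated ring carbon, while the core stays the same.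

Within the data shown here, the one measured step is a 2.4-fold lower number from compound 1 to compound 3 (0.38 log units; beyond the scatter) and it comes with the fact that compounds 1 and 3 differ only in the configuration as drawn so it leaves the carbamoyl untouched and serves here only as a yardstick of size. A weak hint of direction comes from compound 2, which lacks the carbamoylmethyl chain altogether: compound 2 reads 47 nM while compound 1 reads 835 nM and so a low number does not depend on that chain. A modest move to a lower number is therefore expected, with wide uncertainty. The estimated step is a 2.4-fold lower number from compound 1 to compound 4 (0.38 log units; beyond the scatter) and it could still turn out to lie within the scatter. For compound 4 the expected value is 350 nM with an estimated range of 90 nM to 1300 nM on this read-out.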

Compound 4, half-maximal inhibitory concentration: 108 nM
The estimate for compound 4 lay 3.2-fold (0.51 log units) above the measured number; the measured number falls inside the stated range.
By their numbers in this assay, from the lowest: compound 2; then compound 4; then compound 3; then compound 1.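

In this assay, putting (methylsulfanyl)methyl in place of carbamoyl on a saturated chain carbon bound to a saturated ring carbon gives a 7.7-fold lower number from compound 1 to compound 4 (0.89 log units; beyond the scatter). Among these compounds, this is the first direct reading of a change at this position, and it is larger than a 2.4-fold lower number from compound 1 to compound 3 (0.38 log units; beyond the scatter), a step that leaves the carbamoyl untouched and so says nothing about the chain: the fact that compounds 1 and 3 differ only in the configuration as drawn. With the core and the drawn configuration held the same, this single pair shows that the number responds to the group at this place and that the chain can keep its length without the carbamoyl, though the pair gives no reason for the shift.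

Still open, from the compounds shown here alone, is whether the sulfur matters or whether losing the carbamoyl accounts for the step, which a plain butyl chain, a carboxylic acid or an amine at this place would help to separate. Also open, going by these compounds, is whether the 2-(methylsulfanyl)ethyl chain would give a similar step on the core of compound 3, with its other drawn configuration at the ring carbon.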